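Pyrrole Diester Series: Thioester Replacement at One Carbonyl

The compounds below may be only part of what the source reports. "The series", "measured", "known", "first", "only" and "open" are said of these compounds alone.

Measured compounds:
compound 1, `Cc1c(C(=O)OC(C)(C)C)c[nH]c1C(=O)OC(C)(C)C`, 100 nM
compound 2, `Cc1c(C(=O)OC(C)C(C)(C)C)c[nH]c1C(=O)OC(C)(C)C`, 17 nM

Two measured compounds make up this set, both tested in an assay on CHO cells for inhibition of metabotropic glutamate receptor 1 (Rattus norvegicus); on this read-out higher numbers stand for weaker inhibition and lower numbers for stronger inhibition. Compound 1 gives 100 nM, the highest of the two numbers; its nearest neighbour, compound 2, gives 17 nM. Among the compounds with values here, the single measured step is a 5.9-fold lower number from compound 1 to compound 2 (0.77 log units; beyond the scatter), brought about by 1,2,2-trimethylpropyl in place of tert-butyl on an oxygen next to a carbonyl group.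

Compound 3, `Cc1c(C(=O)OC(C)(C)C)c[nH]c1C(=O)Sc1ccccn1`, has not yet been measured. It differs from compound 1 by (pyridin-2-yl)sulfanyl in place of tert-butoxy on a carbonyl carbon. Within the data shown here, no measured step bears directly on this change: the only step available, from compound 1 to compound 2, alters the alkyl part of the other ester and leaves the carbonyl carbon in question untouched. The shared core is the same in all three compounds. With no guide to the size or direction of the change, the expectation is a number near that of compound 1, with a wide range. Compound 3 is therefore expected to give about 150 nM in this assay, estimated to fall between 30 nM and 800 nM. This estimate corresponds to an expected 1.5-fold higher number from compound 1 to compound 3 (0.18 log units; within the scatter).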

Compound 3, half-maximal inhibitory concentration: 3000 nM
Compound 3: the middle estimate sits 20-fold (1.30 log units) below what was measured, outside the stated range (above it).
By their numbers in this assay, from the lowest: compound 2; then compound 1; then compound 3.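

In this assay, the carbonyl carbon that carries tert-butoxy in compound 1 proves sensitive to what is attached there: placing (pyridin-2-yl)sulfanyl on it gives a 30-fold higher number from compound 1 to compound 3 (1.48 log units; beyond the scatter), a large step towards weaker inhibition. Within the data shown here, the earlier compounds could not show this, as the only earlier step, a 5.9-fold lower number from compound 1 to compound 2 (0.77 log units; beyond the scatter), altered the alkyl part of the other ester and went towards stronger inhibition, so the two carbonyl positions have now each been seen to respond, in opposite directions for these two particular changes. Nothing available here accounts for the size or direction of the new step.

The change replaces the oxygen link and the tert-butyl group together with a sulfur link and a pyridine ring, which leaves open which of these parts goes with the weaker inhibition; a tert-butylsulfanyl group or a pyridin-2-yloxy group on the same carbonyl carbon would begin to separate them. Also open, from the compounds shown here alone, is how an amine on that carbonyl carbon would read, and whether (pyridin-2-yl)sulfanyl would give a step of similar size alongside the 1,2,2-trimethylpropyl ester of compound 2.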